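The compounds below may be only part of what the source reports. "The series", "measured", "known", "first", "only" and "open" are said of these compounds alone.

Compound 1 `FC(F)(F)c1ccc(CSc2nc(N3CCN(c4ccccn4)CC3)cc(C(F)(F)F)n2)cc1`: > 50000 nM
Compound 2 `Cc1csc(Sc2cc(C(F)(F)F)nc(SCc3ccc(C(F)(F)F)cc3)n2)n1`: 12000 nM

Both results come from a functional assay on PC-3 cells (Homo sapiens) for inhibition, read by MTT assay, with a stated time of 72 h; on this read-out higher numbers stand for weaker inhibition and lower numbers for stronger inhibition. For compound 1 the entry > 50000 nM is a limit of the assay and not a number. For the measured compounds named here, that leaves compound 2, at 12000 nM, as the only true number so far, and it is the natural reference point for the next compound.

That next compound is compound 3 `FC(F)(F)c1ccc(CSc2nc(Sc3ncc(-c4ccncc4)s3)cc(C(F)(F)F)n2)cc1`, which has not yet been measured. Compared with compound 2, it carries 5-(pyridin-4-yl)-1,3-thiazol-2-yl in place of 4-methyl-1,3-thiazol-2-yl on a sulfur. The rest of the molecule stays the same.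

Going by the values given here, no pair of measured compounds differs in just one place, so the data offer no direct guide to the effect of this swap. The expectation therefore starts from compound 2 at 12000 nM and stays cautious. The expected change, a 1.3-fold higher number from compound 2 to compound 3 (0.10 log units; within the scatter), is small and leans slightly toward weaker inhibition, and it may not clear the usual scatter. For compound 3 the estimated value is 15000 nM, with an expected range from 4000 nM to 50000 nM.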

Compound 3, half-maximal inhibitory concentration: 7350 nM
For compound 3 the middle estimate is 2.0-fold (0.31 log units) above the measured one, within the range that was stated.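

In this assay, for the compounds shown here, replacing 4-methyl-1,3-thiazol-2-yl on the sulfur with 5-(pyridin-4-yl)-1,3-thiazol-2-yl gives a 1.6-fold lower number from compound 2 to compound 3 (0.21 log units; within the scatter), so this is the first direct reading of a change at this place. The entering group is much larger, with 11 heavy atoms against 6 and an additional six-membered aromatic ring, yet the step does not clear the usual scatter, so this single pair shows no real difference in cell growth inhibition from the swap. Compound 1 cannot join this comparison, since it differs from the other two in what sits on the core and its entry is a limit and not a number: the limit of > 50000 nM in this assay, at which 1 of the 3 values shown sits.

The swap removes the methyl and adds the pyridin-4-yl at a different ring place in one step, so these compounds cannot separate the two changes, and a plain 1,3-thiazol-2-yl with no substituent would be needed to do so. Going by these compounds, it also remains open whether the ring nitrogen of the pyridine matters, which a phenyl ring in its place could test, and whether an amine or a carboxylic acid on the thiazole would move the value beyond the scatter.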